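The source may report more compounds than this note shows. Statements on the series, on what has been measured and on what is new or still open speak of the compounds shown alone.

Working notes on the series in a functional assay on MCF7 cells (Homo sapiens) for cytotoxicity, read by MTT assay, with a stated time of 48 h; on this read-out lower numbers stand for stronger inhibition and higher numbers for weaker inhibition. Of the compounds shown here, three bearing a substituted phenyl on the shared core have numbers so far: compound 1 (`COc1ccccc1-c1nnc(SCCn2c([N+](=O)[O-])cnc2C)o1`) gives 10800 nM, compound 2 (`Cc1cccc(-c2nnc(SCCn3c([N+](=O)[O-])cnc3C)o2)c1O`) gives 19900 nM, and compound 3 (`Cc1ccc(-c2nnc(SCCn3c([N+](=O)[O-])cnc3C)o2)c(O)c1`) gives 23500 nM. Compound 3 shares the weak end of this small set with its nearest neighbour, with no separation between them: a 1.2-fold higher number from compound 2 to compound 3 (0.07 log units; within the scatter). The only separation is modest, a 2.2-fold higher number from compound 1 to compound 3 (0.34 log units; beyond the scatter), while the remaining pair shows a 1.8-fold higher number from compound 1 to compound 2 (0.27 log units; within the scatter).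

Compound 4 (`Cc1ncc([N+](=O)[O-])n1CCSc1nnc(-c2cccnc2)o1`) has no number yet. The change is pyridin-3-yl in place of 2-hydroxy-4-methylphenyl on an aromatic carbon, in words pyridin-3-yl in place of 2-hydroxy-4-methylphenyl on an aromatic carbon. The measured steps bear on this only indirectly, as each one swaps one substituted phenyl for another and none introduces a ring with a hetero atom. They do show that this position has so far moved the numbers little, and they offer no direction for the new ring.

The step expected in this assay is therefore none beyond the scatter, and a 1.2-fold lower number from compound 3 to compound 4 (0.07 log units; within the scatter) is the estimated size. For compound 4 the estimated value is 20000 nM, with an expected range of 8000 nM to 50000 nM.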

Compound 4, half-maximal inhibitory concentration: 28700 nM
Beside the measured number, compound 4's estimate is 1.4-fold (0.16 log units) below it; the range from low to high includes it.
By their numbers in this assay, from the lowest: compounds 1, 2, 3 and 4 (each within the scatter of the next, the first and the last beyond it).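

In this assay, pyridin-3-yl, the first ring with a hetero atom at this position, gives no separation from the two hydroxy-methylphenyl compounds: a 1.2-fold higher number from compound 3 to compound 4 (0.09 log units; within the scatter) and a 1.4-fold higher number from compound 2 to compound 4 (0.16 log units; within the scatter). Exchanging a carbon-only aromatic ring that carries a hydrogen-bond donor for a ring with one hetero atom and no donor therefore stays within the scatter, and the position tolerates this larger change in ring type about as well as it tolerated the earlier swaps among substituted phenyls, with the widest step in the set still modest at a 2.7-fold higher number from compound 1 to compound 4 (0.42 log units; beyond the scatter). Nothing available explains why the numbers stay so close across these different rings.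

As far as these compounds go, all four compounds carry a six-membered aromatic ring at this position, so it remains open whether a primary amine, a carboxylic acid or a longer alkyl chain there would move the number clear of this narrow band. Where an unsubstituted phenyl would fall also stays open, so the contribution of the ring nitrogen alone cannot be read from these compounds.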